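Chloro for fluoro on the shared core

The source may hold more compounds than are shown below. What is called first, only, known or untested is meant among the compounds shown, and "the series" means these compounds.

In a functional assay on T98G cells (Homo sapiens) for inhibition, read by MTT assay, with a stated time of 72 h (a lower number here means a stronger inhibitor, a higher number a weaker inhibitor), compound 1 (`CC1(C)CC(NC(=O)Nc2cccc(Cl)c2)c2cc(Br)ccc2O1`) gives 67000 nM and compound 2 (`CC1(C)CC(NC(=O)Nc2cccc(Cl)c2)c2cc(F)ccc2O1`) gives 45000 nM as its reading. Only these two have been measured so far. Compound 2 stands within the scatter of compound 1, so the pair cannot be ranked.

Compound 3 (`CC1(C)CC(NC(=O)Nc2cccc(Cl)c2)c2cc(Cl)ccc2O1`) is the next case: chloro in place of fluoro on an aromatic carbon, of a six-membered aromatic ring of carbon only, with chloro in place of fluoro on an aromatic carbon as the counted difference. The rest of the structure is unchanged.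

Among the measured compounds shown here, one measured step bears on this change, the swap of bromo for fluoro on the same kind of carbon. That step is a 1.5-fold lower number from compound 1 to compound 2 (0.17 log units; within the scatter) and gives no sign of a halogen dependence in the series. With only compound 1 and compound 2 to go on, no step beyond the scatter is expected in this assay for the new halogen, and no direction can be firmly expected.

The expected change is a 1.2-fold higher number from compound 2 to compound 3 (0.09 log units; within the scatter) as estimated here. For compound 3 the estimated value is 55000 nM with an expected range from 30000 nM to 95000 nM as the working figure.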

Compound 3, half-maximal inhibitory concentration: 25000 nM
Compound 3: middle estimate off by 2.2-fold (0.34 log units), on the high side; the measured number lies below the stated range.
By their numbers in this assay, from the lowest: compounds 3, 2 and 1 (each within the scatter of the next, the first and the last beyond it).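

In this assay this aromatic carbon now gives its first halogen step beyond the scatter, though a modest one: chloro in place of bromo gives a 2.7-fold lower number from compound 1 to compound 3 (0.43 log units; beyond the scatter). Chloro in place of fluoro gives a 1.8-fold lower number from compound 2 to compound 3 (0.26 log units; within the scatter), which stays within the scatter, so compound 2 and compound 3 cannot be ranked and the change does not separate these two halogens. Any halogen dependence at this position therefore rests on the single pair of compound 1 and compound 3, with compound 2 within the scatter of both, so the three compounds do not give a clean order across the halogens. No supporting data bear on why chloro and bromo differ at this carbon.

On these data alone, how a group other than a halogen on this carbon, such as a methoxy group, an amine or a carboxylic acid, would read in this assay remains open. As far as these compounds go, it is also open whether the difference between chloro and bromo would persist with a change elsewhere on the shared core, since all three compounds carry the same remainder of the structure.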